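Alkyl variation on the chloro-triazine phenylethylamine series

A few compounds are considered here, and "the series" means these few. Any claim that something is new, unique, unknown or untested is made for them only; others in the source may bear on it.

Measured so far:
compound 1 `C[C@H](Nc1nc(Cl)nc(NC(C)(C)C)n1)c1ccccc1` — 3310 nM
compound 2 `CCNc1nc(Cl)nc(N[C@H](C)c2ccccc2)n1` — 14100 nM
compound 3 `CC[C@@H](C)Nc1nc(Cl)nc(N[C@@H](C)c2ccccc2)n1` — 9770 nM

In an ADME assay on the whole organism for inhibition, with Oryza sativa as the target, with a stated time of 4 days (a lower number here means a stronger inhibitor, a higher number a weaker inhibitor), compound 2 gives 14100 nM, the highest number of the three; against compound 3 the gap lies within the scatter, against compound 1 it lies beyond it. Compound 4 `CC(C)Nc1nc(Cl)nc(N[C@H](C)c2ccccc2)n1` differs from compound 2 by methyl in place of hydrogen on a saturated chain carbon bound to a nitrogen on an aromatic ring and a saturated chain carbon. Going by the values given here, the one measured step that bears on this is a 3.0-fold higher number from compound 1 to compound 3 (0.47 log units; beyond the scatter), where the less branched alkyl on the nitrogen gave the higher number. The change here runs the other way, toward a more branched alkyl, so a modest lowering of the number is expected, a 2.0-fold lower number from compound 2 to compound 4 (0.30 log units; within the scatter). Compound 4 is therefore estimated at 7000 nM, in the range 3000 nM to 16000 nM; compound 3 shows how small such an alkyl step can be.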

Compound 4, half-maximal inhibitory concentration: 5370 nM
Beside the measured number, compound 4's estimate is 1.3-fold (0.12 log units) above it; the range from low to high includes it.
By their numbers in this assay, from the lowest: compounds 1, 4, 3 and 2 (each within the scatter of the next, the first and the last beyond it).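

In this assay, adding methyl on the saturated chain carbon bound to the nitrogen, ethylamino to isopropylamino, gives a 2.6-fold lower number from compound 2 to compound 4 (0.42 log units; beyond the scatter) and shows that a single added carbon at this position can move the number beyond the scatter. Going by these compounds alone, the earlier step, a 3.0-fold higher number from compound 1 to compound 3 (0.47 log units; beyond the scatter), compared only two larger branched groups, whereas this one starts from an unbranched ethyl. In both steps, the more branched alkyl has the lower number.

Going by these compounds, whether a longer unbranched chain such as n-butyl or a ring such as cyclopropyl would follow this pattern remains open. No available evidence bears on the reason for the step.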